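Swapping the Linker on Compound 1

The source may hold more compounds than are shown below. What is called first, only, known or untested is meant among the compounds shown, and "the series" means these compounds.

Of the compounds shown here, three sharing one core have been measured in a functional assay on A549 cells (Homo sapiens) for inhibition, read by CCK-8 assay, with a stated time of 72 h, tested at 1 uM; on this read-out lower numbers stand for a weaker effect and higher numbers for a stronger effect at the one concentration tested. Compound 1, `CN(C)C(=O)c1cc2cnc(Nc3ccc(S(=O)(=O)NCCCN=C=S)cc3)nc2n1C1CCCC1`, stands highest of the three numbers: in this assay compound 1 gives 58.9%. Its nearest neighbour is compound 3, `CN(C)C(=O)c1cc2cnc(Nc3ccc(C(=O)NCCCN=C=S)cc3O)nc2n1C1CCCC1`, which in this assay gives 55.9%, a number that lies within the scatter of repeated measurements and so cannot be ordered against compound 1. The furthest is compound 2, `CN(C)C(=O)c1cc2cnc(Nc3ccc(C(=O)NCCCCN=C=S)cc3F)nc2n1C1CCCC1`, which in this assay gives -7%, a gap to compound 1 that lies well beyond the scatter.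

Compound 4, `CN(C)C(=O)c1cc2cnc(Nc3ccc(NC(=O)CCCN=C=S)cc3)nc2n1C1CCCC1`, has not been measured. Relative to compound 1 it carries a group of 9 heavy atoms (5 carbon, 2 nitrogen, 1 oxygen, 1 sulfur; no ring) in place of a group of 10 heavy atoms (4 carbon, 2 nitrogen, 2 oxygen, 2 sulfur; no ring), on an aromatic carbon, the change sitting on the aromatic carbon para to a large group. Going by the values given here, no pair of measured compounds differs in just one place, so the data give no single-point step to lean on; what they show is that compound 1 and compound 3 sit close together while compound 2 falls far off.

Compound 4 is expected to fall a little below compound 1, a step of a number 13.9 percentage points lower from compound 1 to compound 4 (beyond the scatter), with the drop not clearly beyond the scatter. For compound 4 the estimate in this assay is 45%, between 15% and 70%.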

Compound 4, a percentage reported as inhibition, at one concentration (the size of the read-out at that concentration, not a potency): 56.1%
Estimate against measurement, compound 4: 11.1 percentage points below; measured number inside the range.
By their numbers in this assay, from the lowest: compound 2; then compounds 3, 4 and 1 (each within the scatter of the next).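

In this assay, the group of 9 heavy atoms in place of the group of 10 heavy atoms, on an aromatic carbon para to a large group, gives a number 2.8 percentage points lower from compound 1 to compound 4 (within the scatter), so the two groups cannot be told apart at this position. This is the only comparison among the compounds shown that isolates a single place, and it shows that the position tolerates this swap, even though the entering group has 3 double bonds outside aromatic rings and 3 hydrogen-bond acceptors against 4 of each in the leaving group, with 1 hydrogen-bond donor, no ring and no net charge in both. Nothing measured here bears on why the two groups read alike.

The compounds shown leave open how a group ending in an amine or a carboxylic acid would read at this position. They also leave open whether the two groups would still read alike at other concentrations, since each compound is reported at one concentration only.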